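Furan-3-yl to ethynyl on a methylamino compound

The source may report more compounds than this note shows. Statements on the series, on what has been measured and on what is new or still open speak of the compounds shown alone.

In a functional assay on HL-60 cells (Homo sapiens) for antiproliferative activity, read by XTT assay, with a stated time of 72 h (on this read-out lower numbers stand for stronger inhibition and higher numbers for weaker inhibition), compound 1 `CSc1ncnc2c1c(-c1ccoc1)cn2[C@@H]1O[C@H](CO)[C@@H](O)[C@H]1O` gives 360 nM, and compound 2 `C#Cc1cn([C@@H]2O[C@H](CO)[C@@H](O)[C@H]2O)c2ncnc(SC)c12`, which carries ethynyl in place of furan-3-yl, gives 50 nM. Compound 3 `CNc1ncnc2c1c(-c1ccoc1)cn2[C@@H]1O[C@H](CO)[C@@H](O)[C@H]1O` has methylamino in place of the methylsulfanyl of compound 1. For compound 3 the reading is only a limit of the assay, > 15000 nM, not a number.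

Compound 4 `C#Cc1cn([C@@H]2O[C@H](CO)[C@@H](O)[C@H]2O)c2ncnc(NC)c12` keeps the methylamino group of compound 3 and takes ethynyl in place of furan-3-yl on an aromatic carbon. For the measured compounds named here, two measured steps bear on this change. The same swap, made with methylsulfanyl present, gave a 7.2-fold lower number from compound 1 to compound 2 (0.86 log units; beyond the scatter), and that points to a modest move towards a lower number. The methylamino change gave an at least 41-fold higher number from compound 1 to compound 3 (1.61 log units; beyond the scatter), a large move the other way, so compound 4 is expected to keep a high number in this assay even if the swap helps as much as it did before. The expected move is an at least 6.0-fold lower number from compound 3 to compound 4 (0.77 log units; beyond the scatter), and it is uncertain because the starting point is a limit. For compound 4 the estimated value is 2500 nM, with an expected range from 250 nM to 15000 nM.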

Compound 4, half-maximal inhibitory concentration: 9060 nM
Estimate against measurement, compound 4: 3.6-fold (0.56 log units) below; measured number inside the range.
By their numbers in this assay, from the lowest: compound 2; then compound 1; then compound 4. At a limit, above all of these: compound 3.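

With ethynyl on the aromatic carbon, methylamino in place of methylsulfanyl again moves the number up in this assay, and here both ends are measured, so the size of the loss can be read: the step is a 180-fold higher number from compound 2 to compound 4 (2.26 log units; beyond the scatter). For compound 3 the reading > 15000 nM is a limit of the assay, not a number. Ethynyl in place of furan-3-yl on the methylamino core gives an at least 1.6-fold lower number from compound 3 to compound 4 (0.21 log units; that floor lies within the scatter), so the floor alone does not show a gain beyond the scatter, although the true gain may be larger.

Going by these compounds, whether this swap helps as much with methylamino as it does with methylsulfanyl stays open, and so does whether methylamino costs the same with either group on the aromatic carbon, with only a floor for one step of each pair. Also open, on these data alone, is how the number would move with an unsubstituted amine or dimethylamino in place of methylamino, or with a longer chain such as propynyl in place of ethynyl.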